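This account rests on a few compounds, and the source may have more. Where it says the series, first, only, none or still open, it means among the compounds named here.

Measured so far in an ADME assay on L02 cells (Homo sapiens) for antiproliferative activity, read by MTT assay, with a stated time of 48 h; on this read-out lower numbers stand for stronger inhibition and higher numbers for weaker inhibition:

- Compound 1 `CCn1c(C(=O)N(CCC#N)CCC#N)ccc1C(CC)(CC)c1ccc(OCCC(O)(CC)CC)c(C)c1`: 37800 nM
- Compound 2 `CCOc1ccc(NC(=O)c2ccc(C(CC)(CC)c3ccc(OCCC(O)(CC)CC)c(C)c3)n2CC)cc1`: > 50000 nM

The value of compound 2, > 50000 nM, is a limit of this assay and not a number. Compound 3 `CCn1c(C(=O)N(C)CC(=O)O)ccc1C(CC)(CC)c1ccc(OCCC(O)(CC)CC)c(C)c1` keeps the shared core but carries (carboxymethyl)(methyl)amino in place of (4-ethoxyphenyl)amino on a carbonyl carbon. Going by the values given here, only one measured step bears on this change, since it swaps groups at the same carbonyl carbon: an at least 1.3-fold higher number from compound 1 to compound 2 (0.12 log units; that floor lies within the scatter). Because that step is only a floor, it gives no firm size to carry over. The expectation therefore rests mainly on compound 1, which carries yet another group there and gives 37800 nM. No change beyond the scatter is expected in this assay, and the estimated step is an at least 1.1-fold lower number from compound 2 to compound 3 (0.04 log units; that floor lies within the scatter). For compound 3 the expected value is 45000 nM, within an estimated range from 20000 nM to 100000 nM.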

Compound 3, half-maximal inhibitory concentration: 2150 nM
Estimate against measurement, compound 3: 21-fold (1.32 log units) above; the measured number lies below the stated range.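

Until now, the group on this carbonyl carbon had shown no change beyond the scatter, but in this assay the swap to (carboxymethyl)(methyl)amino gives an at least 23-fold lower number from compound 2 to compound 3 (1.36 log units; beyond the scatter). The same group also stands apart from the group of 9 heavy atoms, with an 18-fold lower number from compound 1 to compound 3 (1.25 log units; beyond the scatter), so the large drop in the number appears against both earlier groups and this position can strongly change the read-out. Compound 2 stands at a limit of the assay and not at a number: the limit of > 50000 nM in this assay, at which 1 of the 3 values shown sits.

The compounds shown leave open which part of (carboxymethyl)(methyl)amino goes with the lower number, the carboxylic acid or the methyl. A methyl ester in place of the carboxylic acid, or a longer chain carrying that acid, would help to separate these parts.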